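The source may hold more compounds than are shown below. What is called first, only, known or untested is meant among the compounds shown, and "the series" means these compounds.

Measured in a functional assay on MCF7 cells (Homo sapiens) for antiproliferative activity, with a stated time of 72 h; a higher number here means a weaker inhibitor, a lower number a stronger inhibitor:
- Compound 1 `COc1cc(OCC(=O)NO)ccc1CNCCn1cnc2ccccc21`: > 10000 nM, a limit of the assay
- Compound 2 `O=C(COc1ccc(CNCCn2cnc3ccccc32)c(F)c1)NO`: 539 nM
- Compound 3 `Cc1[nH]c2ccccc2c1C1=CCC(NCc2ccc(OCC(=O)NO)cc2)CC1`: 898 nM

Compound 3, at 898 nM, lies within the usual scatter of compound 2. Compound 4 `Cc1[nH]c2ccccc2c1C1=CCC(NCc2ccc(OCC(=O)NO)cc2F)CC1` differs from compound 3 by fluoro in place of hydrogen on an aromatic carbon. For the measured compounds named here, only one measured step bears on this, an at least 18-fold lower number from compound 1 to compound 2 (1.26 log units; beyond the scatter). It starts from compound 1, which sits at the limit of > 10000 nM in this assay, at which 1 of the 3 values shown sits. That step replaces methoxy rather than hydrogen, on a different core, so it bears only weakly on the new change. No step beyond the scatter is therefore expected in this assay, and the expected step is a 1.3-fold lower number from compound 3 to compound 4 (0.11 log units; within the scatter). For compound 4 the estimated value is 700 nM, with an expected range of 250 nM to 2000 nM.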

Compound 4, half-maximal inhibitory concentration: 912 nM
Beside the measured number, compound 4's estimate is 1.3-fold (0.11 log units) below it; measured number inside the range.
By their numbers in this assay, from the lowest: compounds 2, 3 and 4 (each within the scatter of the next). At a limit, above all of these: compound 1.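

In this assay, fluoro in place of hydrogen on this aromatic carbon, ortho to a large group, gives a 1.0-fold higher number from compound 3 to compound 4 (0.01 log units; within the scatter). On the core of compound 3, this position therefore takes a fluoro with no step beyond the scatter, which the earlier step of an at least 18-fold lower number from compound 1 to compound 2 (1.26 log units; beyond the scatter), where methoxy leaves on a different core, could not show. Nothing measured here offers a cause for this result.

The compounds shown leave open how methoxy or an amine at this position on the core of compound 3 would read in this assay.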